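The compounds below may be only part of what the source reports. "The series", "measured", "known", "first", "only" and "open" are said of these compounds alone.

Of the compounds shown here, two in this set have been measured in a physicochemical assay for lipophilicity, measured as octanol-water partition; a lower number here means a more polar compound, a higher number a more lipophilic compound. Compound 1 `O=[N+]([O-])c1ccccc1-c1nc2ccccc2[nH]1` gives 3.07 in this assay. Compound 2 `O=C(c1cccnc1)n1c(-c2ccccc2Cl)nc2ccccc21` gives 4.7 in this assay, the higher of the two numbers, standing beyond the scatter above compound 1.

The step under consideration leads from compound 2 to compound 3 `O=C(c1cccnc1)n1c(-c2cccc(Cl)c2)nc2ccccc21`, the change being (3-chlorophenyl in place of 2-chlorophenyl on an aromatic carbon). The two compounds hold the same atoms, joined differently: a 3-chlorophenyl in place of a 2-chlorophenyl on an aromatic carbon, with no change in the count of hydrogen-bond donors or acceptors and no change in charge. Within the data shown here, no pair of measured compounds shows a step of this kind, so the size of the step cannot be read from the data; the change is expected to leave this assay within the scatter, or at most move it slightly upward.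

Compound 3 is therefore expected to give about 4.8 in this assay, between 4.4 and 5.2. This estimate means an expected step of a number 0.10 log units higher from compound 2 to compound 3 (within the scatter), not beyond the scatter.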

Compound 3, partition coefficient: 4.7
For compound 3 the middle estimate is 0.10 log units above the measured one; low and high end bracket the measured number.
By their numbers in this assay, from the lowest: compound 1; then compounds 2 and 3 (each within the scatter of the next).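

In this assay, 3-chlorophenyl in place of 2-chlorophenyl on the aromatic carbon of the five-membered ring brings no change at the digits printed from compound 2 to compound 3 (within the scatter) and gives the set its first step that differs in one place. Within this pair, therefore, the assay does not separate the two chlorophenyl groups, something the earlier compounds could not show because compound 1 differs from compound 2 in more than one place. Nothing available explains why the two compounds read alike.

Going by these compounds, it remains open whether 4-chlorophenyl, unsubstituted phenyl, or a phenyl ring bearing a carboxylic acid or an amine would read the same on this carbon. On these data alone, it is also open whether this exchange would give the same result without the (pyridin-3-yl)carbonyl group on the neighbouring ring atom.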